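Removing the iodo group from compound 3

The source may hold more compounds than are shown below. What is called first, only, known or untested is meant among the compounds shown, and "the series" means these compounds.

In a functional assay on M21 cells (Homo sapiens) for antiproliferative activity, read by sulforhodamine B assay, with a stated time of 48 h (a higher number here means a weaker inhibitor, a lower number a stronger inhibitor), compound 3 `O=C1NCCN1c1ccc(S(=O)(=O)Nc2ccc(I)cc2)cc1` gives 260 nM, level with compound 2 `O=C1NCCN1c1ccc(S(=O)(=O)Nc2ccc(F)cc2)cc1` at 230 nM. Compound 1 `Cc1cccc(NS(=O)(=O)c2ccc(N3CCNC3=O)cc2)c1` gives a lower number, 69 nM.

Compound 4 `O=C1NCCN1c1ccc(S(=O)(=O)Nc2ccccc2)cc1` carries hydrogen in place of iodo on an aromatic carbon.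

The closest evidence is the exchange of fluoro for iodo at that same place, a 1.1-fold higher number from compound 2 to compound 3 (0.05 log units; within the scatter). The steps of a 3.3-fold higher number from compound 1 to compound 2 (0.52 log units; beyond the scatter) and a 3.8-fold higher number from compound 1 to compound 3 (0.58 log units; beyond the scatter) are larger, but both start from the 3-methylphenyl group, which compound 4 lacks, so they bear on it less directly. Among the compounds with values here, no measured compound yet has the plain phenyl group.

The expected step is a 1.1-fold lower number from compound 3 to compound 4 (0.05 log units; within the scatter), so no change beyond the scatter is anticipated. Compound 4 is estimated at 230 nM, with an expected range of 100 nM to 520 nM.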

Compound 4, half-maximal inhibitory concentration: 200 nM
Beside the measured number, compound 4's estimate is 1.2-fold (0.06 log units) above it; low and high end bracket the measured number.
By their numbers in this assay, from the lowest: compound 1; then compounds 4, 2 and 3 (each within the scatter of the next).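

In this assay, replacing iodo with hydrogen stays within the scatter (a 1.3-fold lower number from compound 3 to compound 4 (0.11 log units; within the scatter)), as does replacing fluoro with hydrogen (a 1.2-fold lower number from compound 2 to compound 4 (0.06 log units; within the scatter)), so hydrogen, fluoro and iodo at this place on the ring give no distinct reading. Only the third comparison lies beyond the scatter (a 2.9-fold higher number from compound 1 to compound 4 (0.46 log units; beyond the scatter)), which sets the 3-methylphenyl group of compound 1 apart from plain phenyl. Nothing measured here accounts for either finding. The compounds shown leave open whether an amine or a carboxylic acid at the place iodo held would shift the number beyond the scatter.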